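Methoxy in Place of Hydrogen: From Compound 2 to Compound 3

The source may hold more compounds than are shown below. What is called first, only, known or untested is meant among the compounds shown, and "the series" means these compounds.

Compound 1 `COc1ccc(-c2cc(Cl)cc(C(=O)Nc3nn[nH]n3)n2)cc1` reaches 100% in a functional assay on the whole organism with Rattus norvegicus as the target, at a dose of 3 mg/kg by the oral route; a lower number here means a weaker effect, a higher number a stronger effect of the compound at the dose given. Compound 2 `O=C(Nc1nn[nH]n1)c1cccc(-c2ccccc2)n1` gives 74% in this assay, the lowest of the two numbers; compound 1 lies higher by a margin beyond the usual scatter. No single-change comparison between these two exists, as compound 1 carries both a chloro group and a methoxy group that compound 2 lacks, so their two values alone are all that can be said of the pair.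

Compound 3 `COc1ccc(-c2cccc(C(=O)Nc3nn[nH]n3)n2)cc1` differs from compound 2 by one change: methoxy in place of hydrogen on an aromatic carbon. Because compound 1, which holds this methoxy group, gives 100% in this assay, the step from compound 2 to compound 3 is expected to be upward and beyond the scatter, estimated as a number 14 percentage points higher from compound 2 to compound 3 (beyond the scatter). In this assay compound 3 is therefore expected to give about 88%, in a range from 70% to 100%.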

Compound 3, a percentage reported as inhibition, in the whole organism at one dose (the size of the read-out at that dose, not a potency): 36%
Beside the measured number, compound 3's estimate is 52 percentage points above it; measured number below the stated range.
By their numbers in this assay, from the lowest: compound 3; then compound 2; then compound 1.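

In this assay, methoxy in place of hydrogen on an aromatic carbon, para to a large group, gives a number 38 percentage points lower from compound 2 to compound 3 (beyond the scatter), which shows that this group alone does not bring the read-out up on the core without chloro. Hydrogen in place of chloro on an aromatic carbon gives a number 64 percentage points lower from compound 1 to compound 3 (beyond the scatter), the first single change to show how much the read-out at this dose can shift with the chloro group while methoxy stays in place. No measurement at hand accounts for the direction or size of either step.

The compounds shown leave open whether methoxy would lower the read-out in the same way on a core that also carries chloro. They also leave open how a hydroxyl group, an amine or a fluoro group would fare at the methoxy position.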